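From 2-Methoxyethoxy to Methoxy: An Expected Flat Step

A few compounds are considered here, and "the series" means these few. Any claim that something is new, unique, unknown or untested is made for them only; others in the source may bear on it.

Three compounds on a shared core have been examined in an assay on CHO cells for displacement of a labelled ligand from adenosine receptor A1 (Homo sapiens), read by scintillation counting, tested at 10 uM; a lower number here means less inhibition, a higher number more inhibition at the concentration tested (going by the name of the read-out). Compound 1 `CC(C)(C)Cc1c(-c2ccccn2)sc(N)c1C(=O)c1ccc(Cl)cc1` gives 1% in this assay. Compound 2 `CC(C)(C)Cc1c(-c2c(F)cccc2F)sc(N)c1C(=O)c1ccc(Cl)cc1` gives 1%, and the step of no change at the digits printed from compound 1 to compound 2 (within the scatter) shows that changing the aromatic substituent left the read-out where it was. Compound 3 `COCCOc1ccc(-c2sc(N)c(C(=O)c3ccc(Cl)cc3)c2CC(C)(C)C)cc1` gives 1% in this assay, level with compound 1 and compound 2 at the digits shown.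

Compound 4 `COc1ccc(-c2sc(N)c(C(=O)c3ccc(Cl)cc3)c2CC(C)(C)C)cc1` is the next compound, and its difference from compound 3 is hydrogen in place of methoxymethyl on a saturated chain carbon bound to an oxygen on an aromatic ring. For the measured compounds named here, no measured step touches this part of the molecule; the only measured step, no change at the digits printed from compound 1 to compound 2 (within the scatter), concerns a different position and stayed within the scatter. All three measured compounds sit at the bottom of the scale in this assay, so there is no room for a downward step and no measured evidence for an upward one.

The expected step is therefore a number 1 percentage points higher from compound 3 to compound 4 (within the scatter), with no change beyond the scatter. Compound 4 is estimated at 2%, with a range from 0% to 12%.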

Compound 4, a percentage reported as inhibition, at one concentration (the size of the read-out at that concentration, not a potency): 1%
Estimate against measurement, compound 4: 1 percentage points above; the range from low to high includes it.
By their numbers in this assay, from the lowest: compounds 1, 2, 3 and 4 (each within the scatter of the next).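

For the compounds shown here, at this position, removing methoxymethyl to turn 2-methoxyethoxy into methoxy gave no change at the digits printed from compound 3 to compound 4 (within the scatter) in this assay, the first measured step to touch this part of the molecule. The 4-methoxyphenyl group also joins the aromatic groups that leave the read-out level, with no change at the digits printed from compound 2 to compound 4 (within the scatter) and no change at the digits printed from compound 1 to compound 4 (within the scatter). Nothing available explains why the read-out stays the same across these changes.

With all four compounds level at the bottom of the scale, the shown compounds cannot tell whether this position matters on a compound with appreciable inhibition. Going by these compounds, it remains open whether an amine, a carboxylic acid or a longer chain in place of methoxymethyl would move the read-out at all.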